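A few compounds are considered here, and "the series" means these few. Any claim that something is new, unique, unknown or untested is made for them only; others in the source may bear on it.

Compound 2 `COc1cc(OCc2cccc(-c3cnc(OC)nc3)c2)c2cc(-c3cn4nc(OC)sc4n3)oc2c1` is the lower of the two numbers in an ADME assay on microsomes from liver (Rattus norvegicus) for metabolic stability (on this read-out higher numbers stand for a longer-lived compound and lower numbers for a shorter-lived compound), where compound 2 gives 1.03 h. Compound 1 `COc1cc(OCc2cccc(-c3ccc(C#N)cc3)c2)c2cc(-c3cn4nc(OC)sc4n3)oc2c1` gives 1.67 h, and the step of a 1.6-fold lower number from compound 1 to compound 2 (0.21 log units; within the scatter) lies within the scatter. Compound 3 `COc1cc(OCc2csc(-c3ccc(C(=O)O)cc3)n2)c2cc(-c3cn4nc(OC)sc4n3)oc2c1` gives > 2 h, which is a limit of the assay and not a number, so compound 3 stands at the limit of > 2 h in this assay, at which 1 of the 3 values shown sits. Compound 4 `COc1cc(OCc2cccc(OCc3ccccc3)c2)c2cc(-c3cn4nc(OC)sc4n3)oc2c1` carries the change (benzyloxy in place of 2-methoxypyrimidin-5-yl on an aromatic carbon). Among the measured compounds shown here, the only measured step at the same position, a 1.6-fold lower number from compound 1 to compound 2 (0.21 log units; within the scatter), stayed within the scatter, so no step beyond the scatter is expected here either; the expected step is a 1.0-fold lower number from compound 2 to compound 4 (0.01 log units; within the scatter). Compound 4 is therefore estimated at 1 h, with a range from 0.5 h to 2 h.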

Compound 4, half-life: 0.333 h
The estimate for compound 4 lay 3.0-fold (0.48 log units) above the measured number, and the stated range ends above it.
By their numbers in this assay, from the lowest: compound 4; then compounds 2 and 1 (each within the scatter of the next). At a limit, above all of these: compound 3.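

On this position, benzyloxy gives a 3.1-fold lower number from compound 2 to compound 4 (0.49 log units; beyond the scatter) in this assay, and it gives a 5.0-fold lower number from compound 1 to compound 4 (0.70 log units; beyond the scatter). Both steps lie beyond the scatter, whereas the step between 4-cyanophenyl and 2-methoxypyrimidin-5-yl did not, so the position does respond to the group placed on it. Nothing at hand accounts for this drop. On these data alone, it stays open whether the step follows the oxygen link or the outer ring of benzyloxy. A benzylamino group or a methoxy group at this place would help separate the two.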